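Plasma half-life notes on a coumarin-ester pair

A few compounds are considered here, and "the series" means these few. Any claim that something is new, unique, unknown or untested is made for them only; others in the source may bear on it.

Measured so far:
compound 1 `CC1=C(CC(=O)OCCOc2ccc3oc(=O)ccc3c2)c2cc(F)ccc2/C1=C\c1ccc([S+](C)[O-])cc1`: > 4 h
compound 2 `CC(C(=O)OCCOc1ccc2oc(=O)ccc2c1)c1cccc(C(=O)c2ccccc2)c1`: 0.517 h
compound 3 `CC1=C(CC(=O)OCCOc2ccc3ccc(=O)oc3c2)c2cc(F)ccc2/C1=C\c1ccc([S+](C)[O-])cc1`: > 4 h

In an ADME assay on a cell-free system (plasma, Homo sapiens) for metabolic stability, read by LC-MS (a lower number here means that the compound disappears faster, a higher number that the compound lasts longer), compound 1 gives > 4 h, which is a limit of the assay and not a number. Compound 3 likewise gives > 4 h in this assay, again a limit. For the measured compounds named here, compound 2 gives 0.517 h, the only number among the three values. The difference between the core of compound 1 and the core of compound 2 is not broken down here.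

Compound 1 and compound 3 differ by one change, (a group of 11 heavy atoms (9 carbon, 2 oxygen; one six-membered aromatic ring of carbon only, one six-membered aromatic ring with 1 hetero atom) in place of a group of 11 heavy atoms (9 carbon, 2 oxygen; one six-membered aromatic ring of carbon only, one six-membered aromatic ring with 1 hetero atom), on an oxygen on a saturated carbon). The step it made, a step that the two limits leave unreadable from compound 1 to compound 3, cannot be read, since the limit of > 4 h in this assay, at which 2 of the 3 values shown sit, leaves both ends of the pair at the same limit. The same change returns from compound 2 to the not yet measured compound 4 `CC(C(=O)OCCOc1ccc2ccc(=O)oc2c1)c1cccc(C(=O)c2ccccc2)c1`: a group of 11 heavy atoms (9 carbon, 2 oxygen; one six-membered aromatic ring of carbon only, one six-membered aromatic ring with 1 hetero atom) in place of a group of 11 heavy atoms (9 carbon, 2 oxygen; one six-membered aromatic ring of carbon only, one six-membered aromatic ring with 1 hetero atom), on an oxygen on a saturated carbon. Going by the values given here, the surroundings of the place are identical in both pairs, so it is the same change, but no measured step tells its size.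

For compound 4 the expectation therefore rests on compound 2 alone, whose value 0.517 h is the only anchor, and the step from compound 2 to compound 4 is estimated as a 1.1-fold higher number from compound 2 to compound 4 (0.03 log units; within the scatter), within the usual scatter. Compound 4 is thus expected to give about 0.55 h in this assay, with a range estimated from 0.2 h to 1.6 h.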

Compound 4, half-life: 0.2 h
Compound 4: middle estimate off by 2.8-fold (0.44 log units), on the high side; low and high end bracket the measured number.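

On the core of compound 2, exchanging one group for another made of the same atoms joined differently, on an oxygen on a saturated carbon, has a readable size in this assay: the change gives a 2.6-fold lower number from compound 2 to compound 4 (0.41 log units; beyond the scatter). On the core of compound 1 the same change cannot be read, because compound 1 and compound 3 both sit at a limit of the assay and not at a number: the limit of > 4 h in this assay, at which 2 of the 4 values shown sit. The change is therefore sized on one core only, so the series shows that it can matter on the core of compound 2 but not that this size or even this direction carries over to the core of compound 1, and a difference between the two cores can be neither claimed nor ruled out.

Still open, from the compounds shown here alone, are the actual half-lives of compound 1 and compound 3, and whether a core with a half-life that can be read throughout would repeat the step seen on the core of compound 2. All four compounds carry an ester, so the notes also leave open how the half-life and this change would behave with an amide in its place, or with a longer chain on the ester oxygen.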